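Chloro for Nitro: One Change on Two Cores

The source may hold more compounds than are shown below. What is called first, only, known or untested is meant among the compounds shown, and "the series" means these compounds.

Measured compounds:
compound 1, `Cc1ccc(OCc2cn(Cc3cccc([N+](=O)[O-])c3)nn2)cc1`, 12.1 ug/mL
compound 2, `Cc1ccc(OCc2cn(Cc3cccc(Cl)c3)nn2)cc1`, 16.3 ug/mL
compound 3, `O=[N+]([O-])c1ccc(Cn2cc(COc3ccc(Cl)cc3)nn2)cc1`, 24.2 ug/mL

In a physicochemical assay, read by spectrophotometry, with a stated time of 30 min (on this read-out higher numbers stand for weaker inhibition and lower numbers for stronger inhibition), compound 1 gives 12.1 ug/mL and compound 2 gives 16.3 ug/mL. The change between them, (chloro in place of nitro on an aromatic carbon), made a 1.3-fold higher number from compound 1 to compound 2 (0.13 log units; within the scatter). Compound 3 gives 24.2 ug/mL; it differs from compound 1 in more than one place, and the difference between the two cores is not broken down here. Compound 4, `Clc1ccc(Cn2cc(COc3ccc(Cl)cc3)nn2)cc1`, awaits measurement and differs from compound 3 by chloro in place of nitro on an aromatic carbon. This is the same kind of change as that from compound 1 to compound 2, though the place differs: meta to a large group in the first pair, para to a large group in the second. The expected step is estimated as a 1.2-fold higher number from compound 3 to compound 4 (0.09 log units; within the scatter), resting on the measured step of a 1.3-fold higher number from compound 1 to compound 2 (0.13 log units; within the scatter) staying within the scatter. Compound 4 is therefore expected near 30 ug/mL, estimated to fall between 15 ug/mL and 60 ug/mL.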

Compound 4, half-maximal inhibitory concentration: 26.1 ug/mL
Estimate against measurement, compound 4: 1.1-fold (0.06 log units) above; low and high end bracket the measured number.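

In this assay the change of chloro in place of nitro on an aromatic carbon gave a step (from the new pair: a 1.1-fold higher number from compound 3 to compound 4 (0.03 log units; within the scatter)) that lies within the scatter, as did the same change on the core of compound 1 (a 1.3-fold higher number from compound 1 to compound 2 (0.13 log units; within the scatter)). Across these two pairs, then, the change carried from one core to the other without a step that the read-out can separate from repeated-measurement noise, but two pairs do not establish a rule for the series or show that the two groups are interchangeable on other cores. No measurement shown here bears on why the steps are this small.

The compounds shown leave open how an amine or a carboxylic acid would read on that same aromatic carbon. They also leave open whether the change would stay within the scatter on a third core.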